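The source may report more compounds than this note shows. Statements on the series, on what has been measured and on what is new or still open speak of the compounds shown alone.

In a functional assay on MCF7 cells (Homo sapiens) for cytotoxicity, read by MTT assay, with a stated time of 48 h (a higher number here means a weaker inhibitor, a lower number a stronger inhibitor), compound 3 `CCCCCCCCCCCCNC(=O)[C@@H](NC(=O)c1ccccc1)[C@@H](C)O` gives 36600 nM, the second highest of the three numbers. Compound 2 `CCCCCCCCNC(=O)[C@@H](NC(=O)c1ccccc1)[C@@H](C)O` gives 111000 nM, while compound 1 `CCCCCCCCCCCCCCNC(=O)[C@@H](N)[C@@H](C)O` gives 10700 nM. Among the measured compounds shown here, the one step that can be read between measured compounds, a 3.0-fold lower number from compound 2 to compound 3 (0.48 log units; beyond the scatter), concerns the alkyl chain and not the acyl group. Compound 4 `C/C=C/C=C/C(=O)N[C@H](C(=O)NCCCCCCCCCCCC)[C@@H](C)O` differs from compound 3 by penta-1,3-dien-1-yl in place of phenyl on a carbonyl carbon. For the measured compounds named here, no measured step bears on an exchange at this carbonyl carbon; the series gives no guide for it, so nothing beyond the scatter is assumed in this assay. The expected step is therefore a 1.0-fold lower number from compound 3 to compound 4 (0.01 log units; within the scatter). For compound 4 the estimate in this assay is 36000 nM, with a range from 9000 nM to 140000 nM.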

Compound 4, half-maximal inhibitory concentration: 37100 nM
Compound 4: middle estimate off by 1.0-fold (0.01 log units), on the low side, and the stated range covers the measured number.
By their numbers in this assay, from the lowest: compound 1; then compounds 3 and 4 (each within the scatter of the next); then compound 2.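

In this assay, the exchange at the carbonyl carbon whose other neighbour is an amide-type nitrogen gives a 1.0-fold higher number from compound 3 to compound 4 (0.01 log units; within the scatter). Among the compounds shown here, this is the first reading at this position, and it shows that an aromatic ring is not needed there to keep the number of compound 3: the open penta-1,3-dien-1-yl chain serves alike on this scaffold. No measured evidence bears on why the two groups read alike.

Open, as far as these compounds go, is whether a saturated hexyl chain, a pyridyl ring or a carboxylic acid at this carbon would also leave the number in place. Also open, from the compounds shown here alone, is whether the same exchange reads alike on the shorter chain of compound 2.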